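This account rests on a few compounds, and the source may have more. Where it says the series, first, only, none or still open, it means among the compounds named here.

Among the compounds with values here, compound 2 `c1ccc(-c2noc(-c3cc4ccccc4[nH]3)n2)cc1` is one of two compounds measured in a functional assay on MCF7 cells (Homo sapiens) for antiproliferative activity, read by WST assay, with a stated time of 72 h; on this read-out lower numbers stand for stronger inhibition and higher numbers for weaker inhibition. There compound 2 gives 45700 nM, the higher of the two numbers; compound 1 `Cc1noc(-c2cc3cc(F)ccc3[nH]2)n1` gives 12400 nM, a lower number, and that gap lies beyond the scatter. Compound 3 `Clc1ccc2[nH]c(-c3nc(-c4ccccc4)no3)cc2c1` is not yet measured; it differs from compound 2 by chloro in place of hydrogen on an aromatic carbon. Within the data shown here, no measured pair shows this change, so only a modest shift toward a lower number is expected, close to the scatter, as a 1.8-fold lower number from compound 2 to compound 3 (0.26 log units; within the scatter). Compound 3 is therefore estimated in this assay at 25000 nM, between 8000 nM and 70000 nM.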

Compound 3, half-maximal inhibitory concentration: 29100 nM
The estimate for compound 3 lay 1.2-fold (0.07 log units) below the measured number, within the range that was stated.
By their numbers in this assay, from the lowest: compound 1; then compounds 3 and 2 (each within the scatter of the next).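

In this assay, within the data shown here, the first single-place step puts chloro in place of hydrogen on an aromatic carbon, meta to a fused ring and para to a fused ring, and gives a 1.6-fold lower number from compound 2 to compound 3 (0.20 log units; within the scatter). This position therefore accepts chloro, with compound 2 and compound 3 not told apart by this read-out. Nothing measured here gives a reason for this result. The compounds shown leave open whether an amine or a carboxylic acid on the same carbon would move the number beyond the scatter.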